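Trifluoromethyl in place of chloro: series notes

The compounds below may be only part of what the source reports. "The series", "measured", "known", "first", "only" and "open" are said of these compounds alone.

Measured so far in a functional assay on SNB-75 cells (Homo sapiens) for inhibition, read by sulforhodamine B assay, with a stated time of 48 h; on this read-out higher numbers stand for weaker inhibition of growth and lower numbers for stronger inhibition of growth:
- compound 1 `COc1cc(-c2nn(-c3cccc(NC(=O)Nc4ccc(Cl)c(Cl)c4)c3)cc2-c2ccncc2)ccc1Cl` gives 1050 nM 
- compound 2 `O=C(Nc1cccc(-n2cc(-c3ccncc3)c(-c3ccc(Cl)c(O)c3)n2)c1)Nc1ccc(Cl)c(Cl)c1` gives 1090 nM 

Compound 2 stands level with compound 1: a 1.0-fold higher number from compound 1 to compound 2 (0.02 log units; within the scatter) lies within the scatter. The next compound is compound 3 `O=C(Nc1cccc(-n2cc(-c3ccncc3)c(-c3ccc(Cl)c(O)c3)n2)c1)Nc1ccc(Cl)c(C(F)(F)F)c1` with trifluoromethyl in place of chloro on an aromatic carbon in the change from 3,4-dichlorophenyl to 4-chloro-3-(trifluoromethyl)phenyl. Within the data shown here, the only measured step, a 1.0-fold higher number from compound 1 to compound 2 (0.02 log units; within the scatter) concerns hydrogen in place of methyl on an oxygen, a different change, so it bears little on this one. No step beyond the scatter is therefore expected in this assay for this exchange. The estimated step is a 1.2-fold lower number from compound 2 to compound 3 (0.08 log units; within the scatter) and stays within the scatter. Compound 3 is expected at 900 nM with an estimated range from 400 nM to 2000 nM in this read-out.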

Compound 3, concentration for 50% growth inhibition: 678 nM
Estimate against measurement, compound 3: 1.3-fold (0.12 log units) above, within the range that was stated.
By their numbers in this assay, from the lowest: compounds 3, 1 and 2 (each within the scatter of the next).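

Trifluoromethyl in place of chloro gives a 1.6-fold lower number from compound 2 to compound 3 (0.21 log units; within the scatter) in this assay, so this position on the 3,4-dichlorophenyl group accepts the exchange without a step beyond the scatter. Among these compounds, the earlier pair tested only hydrogen in place of methyl on an oxygen, so this is the first reading at this position. Nothing available accounts for this result.

From the compounds shown here alone, whether a nitrile or an amine at this position would give a step beyond the scatter remains open. So does whether the exchange reads the same with the methyl on oxygen of compound 1.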